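A Chloro Substituent Tried on a Second Core

A few compounds are considered here, and "the series" means these few. Any claim that something is new, unique, unknown or untested is made for them only; others in the source may bear on it.

Compound 1 `CC(C)CCn1ccc(-c2ccc(OCC3CC3)cc2)c(C#N)c1=O` and compound 2 `CC(C)CCn1ccc(-c2ccc(OCC3CC3)c(Cl)c2)c(C#N)c1=O` share one core and differ in a single place: chloro in place of hydrogen on an aromatic carbon. In a functional assay on CHO cells for positive allosteric modulation of metabotropic glutamate receptor 2 (Homo sapiens), read by scintillation counting and GTPgammaS binding, with a stated time of 30 min (on this read-out higher numbers stand for an effect only at larger amounts of compound and lower numbers for an effect already at smaller amounts), compound 1 gives 290 nM, and compound 2 gives 110 nM. The step is a 2.6-fold lower number from compound 1 to compound 2 (0.42 log units; beyond the scatter).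

Compound 3 `CCCCn1ccc(-c2ccc(Oc3ccnc(C)c3)cc2)c(C#N)c1=O` is built on a different core; how its core differs from that of compound 1 is not broken down here. In this assay compound 3 gives 398 nM. That value and the value of compound 1 lie within the usual scatter of each other, while the gap to compound 2 lies beyond it.

Compound 4 `CCCCn1ccc(-c2ccc(Oc3ccnc(C)c3)c(Cl)c2)c(C#N)c1=O` has not been measured. It differs from compound 3 by chloro in place of hydrogen on an aromatic carbon. Among the compounds with values here, this is the same kind of change as the one from compound 1 to compound 2, but the surroundings are not identical: in compound 2 the chlorine sits ortho to a cyclopropylmethoxy group, whereas in compound 4 it sits ortho to a (2-methylpyridin-4-yl)oxy group; in both it is meta to a large group. Within the data shown here, only one earlier example of this change exists, so the expectation rests on a single step. A step of about a 2.7-fold lower number from compound 3 to compound 4 (0.42 log units; beyond the scatter) is expected, because the same kind of change gave a 2.6-fold lower number from compound 1 to compound 2 (0.42 log units; beyond the scatter). Compound 4 is therefore estimated at 150 nM. For compound 4 the expected range runs from 70 nM to 350 nM.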

Compound 4, half-maximal effective concentration: 166 nM
For compound 4 the middle estimate is 1.1-fold (0.04 log units) below the measured one, and the stated range covers the measured number.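

On the core of compound 3, chloro in place of hydrogen on an aromatic carbon gives a 2.4-fold lower number from compound 3 to compound 4 (0.38 log units; beyond the scatter) in this assay and so moves the number the same way as it did on the core of compound 1. Set side by side, the two steps agree in size, so in this series the change carried over from one core to the other with its effect intact: the same change on two cores in this assay, a 2.6-fold lower number (0.42 log units; beyond the scatter) from compound 1 to compound 2 and a 2.4-fold lower number (0.38 log units; beyond the scatter) from compound 3 to compound 4, 1.1-fold (0.04 log units) apart, within the scatter of two such steps. Still, two cores are a small sample, so this agreement holds for these two pairs only, does not promise the same step on any further core, and does not explain why the number falls.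

The compounds shown leave open whether the step belongs to chlorine in particular, as a fluoro, methyl or methoxy group on the same aromatic carbon could give a smaller, similar or larger step. They also leave open whether the chloro step would keep its size on a compound with a different group elsewhere, such as an amine in place of the (2-methylpyridin-4-yl)oxy group or a longer chain on the ring nitrogen.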